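The source may hold more compounds than are shown below. What is called first, only, known or untested is meant among the compounds shown, and "the series" means these compounds.

Compound 1 `COc1ccc(NC(=O)Nc2nc(Sc3c[nH]c4ccccc34)cc(N3CCN(c4ccccn4)CC3)n2)cc1` — > 50000 nM
Compound 2 `O=C(Nc1ccccc1)Nc1nc(Sc2c[nH]c3ccccc23)cc(N2CCN(Cc3ccccc3)CC2)n1` — > 50000 nM
Compound 3 `Cc1ccc(C)c(NC(=O)Nc2nc(Sc3c[nH]c4ccccc34)cc(N3CCN(Cc4ccccc4)CC3)n2)c1` — > 50000 nM

In a functional assay on A549 cells (Homo sapiens) for inhibition, with a stated time of 72 h (a higher number here means a weaker inhibitor, a lower number a stronger inhibitor), compound 3 reaches only the limit of the assay, > 50000 nM. Compound 1 likewise stops at a limit, > 50000 nM. Compound 2 stops at a limit as well, > 50000 nM. The one step among these, a step that the two limits leave unreadable from compound 2 to compound 3, cannot be read for size. Compound 4 `COc1ccc(NC(=O)Nc2nc(Sc3c[nH]c4ccccc34)cc(N3CCN(Cc4ccccc4)CC3)n2)cc1` differs from compound 3 by 4-methoxyphenyl in place of 2,5-dimethylphenyl on an amide-type nitrogen. Within the data shown here, no measured step bears on this change with a readable size. Compound 4 is expected to sit at the same limit because the limit of > 50000 nM in this assay, at which 3 of the 3 values shown sit, already holds compound 1, which carries the 4-methoxyphenyl group. The step that the limit leaves unreadable from compound 3 to compound 4 is thus expected to stay unreadable. The estimate for compound 4 is 80000 nM, with a range from 20000 nM to 300000 nM.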

Compound 4, half-maximal inhibitory concentration: 42300 nM
Beside the measured number, compound 4's estimate is 1.9-fold (0.28 log units) above it; the measured number falls inside the stated range.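

In this assay, among these compounds, compound 4 gives 42300 nM, the only value of the four that is a number and not a limit. The change to 4-methoxyphenyl on the amide-type nitrogen gives an at least 1.1-fold lower number from compound 3 to compound 4 (0.07 log units; that floor lies within the scatter), methoxy in place of hydrogen on an aromatic carbon gives an at least 1.1-fold lower number from compound 2 to compound 4 (0.07 log units; that floor lies within the scatter), and benzyl in place of pyridin-2-yl on the amine nitrogen in a ring gives an at least 1.1-fold lower number from compound 1 to compound 4 (0.07 log units; that floor lies within the scatter). Each of these steps is only a floor, and most of the set stays at the limit: the limit of > 50000 nM in this assay, at which 3 of the 4 values shown sit.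

As far as these compounds go, the true size of these steps remains open. From the compounds shown here alone, it is also open whether a carboxylic acid in place of methoxy, or a longer chain in place of benzyl, would lower the number further.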